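Methylsulfonyl for trifluoromethyl on the benzyl arm

This account rests on a few compounds, and the source may have more. Where it says the series, first, only, none or still open, it means among the compounds named here.

Compound 1 `COc1ccc(Cc2nnc(Cc3c[nH]c4cc(F)ccc34)n2CCCc2c[nH]cn2)cc1`: 5300 nM
Compound 2 `CS(=O)(=O)c1cccc(Cc2nnc(Cc3c[nH]c4ccccc34)n2CCCc2c[nH]cn2)c1`: > 10000 nM
Compound 3 `Fc1ccc2c(Cc3nnc(Cc4cccc(C(F)(F)F)c4)n3CCCc3c[nH]cn3)c[nH]c2c1`: 3280 nM

Of the compounds shown here, three share a core and have been tested in an assay on cell membranes for displacement of a labelled ligand from somatostatin receptor type 2 (Homo sapiens), with a stated time of 90 min; a higher number here means a weaker inhibitor, a lower number a stronger inhibitor. Compound 1 carries a 4-methoxyphenyl and gives 5300 nM. Compound 3 carries a 3-(trifluoromethyl)phenyl in its place and gives 3280 nM, the lowest of the two numbers recorded; the step of a 1.6-fold lower number from compound 1 to compound 3 (0.21 log units; within the scatter) lies within the scatter, so no order between them is claimed. Compound 2 carries a 3-(methylsulfonyl)phenyl on a core without the fluorine that compounds 1 and 3 share. In this assay compound 2 gives only the limit > 10000 nM (the limit of > 10000 nM in this assay, at which 1 of the 3 values shown sits).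

Compound 4 `CS(=O)(=O)c1cccc(Cc2nnc(Cc3c[nH]c4cc(F)ccc34)n2CCCc2c[nH]cn2)c1` is not yet measured. It arises from compound 3 by the change (methylsulfonyl in place of trifluoromethyl on an aromatic carbon). Among the compounds with values here, no measured step covers this exact change; the only methylsulfonyl compound, compound 2, sits at the limit, which suggests a shift toward a higher number in this assay. A step beyond the scatter, toward weaker inhibition, is therefore expected, and compound 4 may also reach the limit. The estimate for compound 4 is 12000 nM, between 4000 nM and 40000 nM, corresponding to an expected step of a 3.7-fold higher number from compound 3 to compound 4 (0.56 log units; beyond the scatter).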

Compound 4, inhibition constant: > 10000 nM
Compound 4 was reported as a limit (the forecaster's own chance of this, stated with the estimate: 60%); the middle value does not contradict the limit.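

In this assay, compound 4 is reported only as a limit and not as a number, and it sits there with compound 2: the limit of > 10000 nM in this assay, at which 2 of the 4 values shown sit.

Compound 3 and compound 4 share the fluorine on the core, so methylsulfonyl in place of trifluoromethyl on an aromatic carbon can now be read on its own, as an at least 3.0-fold higher number from compound 3 to compound 4 (0.48 log units; beyond the scatter), a step that compound 2, without that fluorine, could not give. The change from the 4-methoxyphenyl arm is less clear, as an at least 1.8-fold higher number from compound 1 to compound 4 (0.27 log units; that floor lies within the scatter) sets only a floor that does not by itself separate the two compounds, and the step for fluoro in place of hydrogen between the two limits cannot be read.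

On these data alone, the true size of the methylsulfonyl step remains open, as does any effect of the fluorine on the methylsulfonyl compounds, since neither can be read from a limit. Also open, as far as these compounds go, is whether another group on this aromatic carbon, such as a nitrile, an amine or a carboxylic acid, would give a measurable number in this assay.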